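Chain terminus change on the lowest of three oral bioavailability values

This account rests on a few compounds, and the source may have more. Where it says the series, first, only, none or still open, it means among the compounds named here.

Measured compounds:
compound 1, `CC(C)(C)C(=O)C1=C(O)C(=O)N(c2ccc(-c3ccon3)cc2)C1c1ccccc1OCCO`, 49.9%
compound 2, `CC(C)(C)C(=O)C1=C(O)C(=O)N(c2ccc(-c3ccsc3)cc2)C1c1ccccc1OCCO`, 39.5%
compound 3, `CC(C)(C)C(=O)C1=C(O)C(=O)N(c2ccc(-c3cccs3)cc2)C1c1ccccc1OCCO`, 65.2%

In an ADME assay on the whole organism (Rattus norvegicus) for pharmacokinetics, at a dose of 1 mg/kg by the oral route (a higher number here means that a larger share of the oral dose reaches the circulation, a lower number that a smaller share of the oral dose reaches the circulation), compound 2 stands lowest of the three. Its nearest neighbour is compound 1: a number 10.4 percentage points lower from compound 1 to compound 2 (beyond the scatter). The furthest is compound 3: a number 25.7 percentage points higher from compound 2 to compound 3 (beyond the scatter). Between the other two, a number 15.3 percentage points higher from compound 1 to compound 3 (beyond the scatter).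

Compound 4, `C[S+]([O-])CCOc1ccccc1C1C(C(=O)C(C)(C)C)=C(O)C(=O)N1c1ccc(-c2ccsc2)cc1`, differs from compound 2 by a group of 3 heavy atoms (1 carbon, 1 oxygen, 1 sulfur; no ring) in place of one oxygen atom, on a saturated chain carbon, two bonds along the chain from an oxygen on an aromatic ring. For the measured compounds named here, every measured step concerns only the aromatic substituent; none touches the chain on the oxygen of the aromatic ring, so no measured step bears on this change, and no step beyond the scatter is expected in this assay. The estimate for compound 4 is 40% (range 20% to 62%), an expected a number 0.5 percentage points higher from compound 2 to compound 4 (within the scatter).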

Compound 4, oral bioavailability: 23.2%
The estimate for compound 4 lay 16.8 percentage points above the measured number; measured number inside the range.
By their numbers in this assay, from the lowest: compound 4; then compound 2; then compound 1; then compound 3.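

The chain on the oxygen of the aromatic ring is not a silent position in this assay: the group of 3 heavy atoms (1 carbon, 1 oxygen, 1 sulfur; no ring) in place of the hydroxy oxygen gives a number 16.3 percentage points lower from compound 2 to compound 4 (beyond the scatter) on an otherwise unchanged structure. Among the compounds shown, the number therefore responds to this chain terminus as well as to the aromatic substituent.

Open, from the compounds shown here alone, is whether an amine, a carboxylic acid or a longer chain at this terminus would hold the number, and whether the same exchange behaves alike with thiophen-2-yl as the aromatic substituent. Nothing at hand accounts for this step.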